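The compounds below may be only part of what the source reports. "The series", "measured", "known", "first", "only" and "open" are said of these compounds alone.

Compound 1 `COC[C@@H](C)n1cc(Cl)nc(Nc2cc(C)c(OC)nc2C)c1=O` gives 39% in an ADME assay on microsomes from liver (Homo sapiens) for metabolic stability, read by HPLC, with a stated time of 10 min, tested at 3 uM; on this read-out higher numbers stand for a more stable compound and lower numbers for a less stable compound
Compound 2 `Cc1cc(Nc2nc(Cl)cn([C@H](C)C3CC3)c2=O)c(C)nc1OC(F)F` gives 100% in this assay

Compound 2 gives 100% and stands highest of the two, beyond the scatter from compound 1. Compound 3 `COC[C@@H](C)n1cc(Cl)nc(Nc2cc(C)c(OC(F)F)nc2C)c1=O` differs from compound 2 in one place: methoxymethyl in place of cyclopropyl on a saturated chain carbon bound to an aromatic nitrogen and a saturated chain carbon on a saturated chain carbon bound to an aromatic nitrogen and a saturated chain carbon. Among the compounds with values here, no measured pair shows this change alone. Compound 1 also carries methoxymethyl, and its 39% suggests a fall beyond the scatter. The expected fall is a number 30 percentage points lower from compound 2 to compound 3 (beyond the scatter) in this assay on this reasoning. Compound 3 is estimated at 70% with a range from 45% to 95% in this measurement.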

Compound 3, percent of the compound remaining: 87%
Compound 3: middle estimate off by 17 percentage points, on the low side, within the range that was stated.
By their numbers in this assay, from the lowest: compound 1; then compound 3; then compound 2.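

In this assay, within the data shown here, the swap of cyclopropyl for methoxymethyl, read alone for the first time, gives a number 13 percentage points lower from compound 2 to compound 3 (beyond the scatter) on the saturated chain carbon. With methoxymethyl held in place, difluoromethyl in place of methyl on the oxygen gives a number 48 percentage points higher from compound 1 to compound 3 (beyond the scatter), so here the group on that oxygen makes the larger step. Nothing measured here explains either step. From the compounds shown here alone, whether an amine or a longer chain on the same carbon would keep the number this high stays open, as does the size of the cyclopropyl swap when the oxygen carries methyl.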